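The source may hold more compounds than are shown below. What is called first, only, known or untested is meant among the compounds shown, and "the series" means these compounds.

- compound 1 `C1=C(CCc2ccccc2)COc2ccccc21` gives 50000 nM
- compound 2 `CC(Cc1ccccc1)C1=Cc2ccccc2OC1` gives 25000 nM
- compound 3 `CC(CC1=Cc2ccccc2OC1)c1ccccc1` is still to be measured

Within the data shown here, in an ADME assay on HeLa cells (Homo sapiens) for cytotoxicity, read by XTT assay (on this read-out lower numbers stand for higher toxicity in this test and higher numbers for lower toxicity in this test), compound 1 gives 50000 nM and the one other measured compound lies within the scatter of it. Compound 3 carries methyl in place of hydrogen on a saturated chain carbon bound to an aromatic carbon and a saturated chain carbon. Among the measured compounds shown here, the one measured methyl step, made on another saturated chain carbon, was a 2.0-fold lower number from compound 1 to compound 2 (0.30 log units; within the scatter) and so no step beyond the scatter is expected in this assay for this change. The expected step is a 1.7-fold lower number from compound 1 to compound 3 (0.22 log units; within the scatter) and would stay within the scatter. For compound 3 the estimated value is 30000 nM, with an expected range of 12000 nM to 60000 nM.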

Compound 3, half-maximal cytotoxic concentration: 12500 nM
Estimate against measurement, compound 3: 2.4-fold (0.38 log units) above; the measured number falls inside the stated range.
By their numbers in this assay, from the lowest: compounds 3, 2 and 1 (each within the scatter of the next, the first and the last beyond it).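

In this assay, among these compounds, the methyl on a saturated chain carbon bound to an aromatic carbon and a saturated chain carbon gives a 4.0-fold lower number from compound 1 to compound 3 (0.60 log units; beyond the scatter), the first step here beyond the scatter, a modest one towards higher toxicity in this test. The other methyl step, a 2.0-fold lower number from compound 1 to compound 2 (0.30 log units; within the scatter), stayed within the scatter, so a single added methyl can shift this read-out measurably at this place. Going by these compounds, whether an ethyl group or a hydroxyl group at this place would shift the number further remains open. No available evidence accounts for this step.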